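A few compounds are considered here, and "the series" means these few. Any claim that something is new, unique, unknown or untested is made for them only; others in the source may bear on it.

Measured compounds:
- compound 1, `CC(C)(C)c1ccc(NC(=O)c2ccc(-c3ncccc3-c3ncc[nH]3)cc2)cc1`: 694 nM
- compound 2, `CC(C)(C)c1ccc(NC(=O)c2ccc(-c3ncccc3-c3nnco3)cc2)cc1`: 59 nM

Of these two numbers in a functional assay for antagonist activity at transient receptor potential cation channel subfamily V member 1 (Rattus norvegicus) (a higher number here means a weaker inhibitor, a lower number a stronger inhibitor), compound 2 has the lower one, and compound 1 sits a step above it: a 12-fold lower number from compound 1 to compound 2 (1.07 log units; beyond the scatter). Compound 3, `CC(C)(C)c1ccc(NC(=O)c2ccc(-c3ncccc3-c3nn[nH]n3)cc2)cc1`, has not yet been measured. It differs from compound 2 in one place: 2H-tetrazol-5-yl in place of 1,3,4-oxadiazol-2-yl on an aromatic carbon. Among the measured compounds shown here, the only measured step that bears on this change is the one from compound 1 to compound 2, where a five-membered ring carrying one hydrogen-bond donor was replaced by one carrying none, and the number fell strongly. Compound 3 brings back a ring with one hydrogen-bond donor, though with four ring nitrogens rather than two. On that basis compound 3 is expected to give a somewhat higher number than compound 2 in this assay, with a step of about a 4.2-fold higher number from compound 2 to compound 3 (0.63 log units; beyond the scatter), though the direction is uncertain. The estimate for compound 3 is 250 nM, within a range from 60 nM to 1000 nM.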

Compound 3, half-maximal inhibitory concentration: > 4000 nM
Compound 3: a limit, no number; the forecaster's own chance of this, stated with the estimate: 5%; middle value at least 16-fold (1.20 log units) away from the limit.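

In this assay the result for compound 3 is a limit of the assay and not a number: the limit of > 4000 nM in this assay, at which 1 of the 3 values shown sits.

Even so, the ring on this aromatic carbon, ortho to a large group, clearly matters: putting 2H-tetrazol-5-yl in place of 1,3,4-oxadiazol-2-yl gives an at least 67-fold higher number from compound 2 to compound 3 (1.83 log units; beyond the scatter), although both rings hold 5 heavy atoms. The tetrazole also compares poorly with the imidazole, another ring with a hydrogen-bond donor, giving an at least 5.7-fold higher number from compound 1 to compound 3 (0.76 log units; beyond the scatter), so the presence of a donor alone does not set the number here.

The compounds shown leave open whether the loss follows the ring hydrogen of the tetrazole or its extra ring nitrogens, as these two features change together. Also open, going by these compounds, is how a tetrazole with a methyl group on that nitrogen, or a carboxylic acid on this carbon, would read in this assay.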